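Opening a ring on the side chain of compound 3

The source may hold more compounds than are shown below. What is called first, only, known or untested is meant among the compounds shown, and "the series" means these compounds.

Measured so far in an assay for binding affinity to Alpha-1B adrenergic receptor (Homo sapiens); a higher number here means a weaker inhibitor, a lower number a stronger inhibitor:
- compound 1 `CN1CCC[C@@H]1Cn1nc(Cc2cccc(F)c2)c2ccccc2c1=O`: 398 nM
- compound 2 `CN1CCC[C@@H]1Cn1nc(Cc2ccc(F)cc2)c2ccccc2c1=O`: 79.4 nM
- compound 3 `CN1CCC(Cn2nc(Cc3ccc(Cl)cc3)c3ccccc3c2=O)C1`: 79.4 nM

All three share one core and differ in two places: the halogen-bearing phenyl group and the amine-bearing side chain. Among the compounds with values here, the only step that can be computed from the measured pair concerns the phenyl group alone: a 5.0-fold lower number from compound 1 to compound 2 (0.70 log units; beyond the scatter). Compound 3 sits level with compound 2 at the digits shown, and the two of them give the lowest numbers of the three; compound 1 gives a higher number than compound 3 by the same margin as that step.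

Compound 4 `CN(C)CCCn1nc(Cc2ccc(Cl)cc2)c2ccccc2c1=O` is not yet measured. It keeps the chlorophenyl group of compound 3 and changes only the side chain: 2-(dimethylamino)ethyl in place of 1-methylpyrrolidin-3-yl on a saturated chain carbon bound to an aromatic nitrogen. Within the data shown here, no measured step touches this part of the molecule, so the measured data offer no guide to its size or direction. With nothing to go on, the expectation is that the change from compound 3 to compound 4 stays within the usual scatter, a 1.3-fold higher number from compound 3 to compound 4 (0.10 log units; within the scatter). Compound 4 is therefore estimated at 100 nM, with a range from 30 nM to 320 nM.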

Compound 4, inhibition constant: 316 nM
Estimate against measurement, compound 4: 3.2-fold (0.50 log units) below; low and high end bracket the measured number.
By their numbers in this assay, from the lowest: compounds 2 and 3 (each within the scatter of the next); then compounds 4 and 1 (each within the scatter of the next).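

In this assay, the side chain turns out not to be indifferent to change: 2-(dimethylamino)ethyl in place of 1-methylpyrrolidin-3-yl gives a 4.0-fold higher number from compound 3 to compound 4 (0.60 log units; beyond the scatter), with the chlorophenyl group and the shared core left untouched. Within the data shown here, this is the only measured step in this part of the molecule, and it shows that opening the ring can matter as much here as a change on the phenyl group does. The two groups match in hydrogen-bond donors, hydrogen-bond acceptors and net charge, and no measurement here explains the higher number.

The compounds shown do not separate the loss of the ring from the change in the chain, so a piperidine ring or a longer chain such as 3-(dimethylamino)propyl at this place remains an open case. Going by these compounds, whether the step would be the same with the 4-fluorophenyl group in place of the chlorophenyl group also remains open.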